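Pyridinyl for Bromophenyl on a Weakly Active Series

The source may hold more compounds than are shown below. What is called first, only, known or untested is meant among the compounds shown, and "the series" means these compounds.

Of the compounds shown here, three built on one shared core have been tested in a functional assay on HeLa cells (Homo sapiens) for antiproliferative activity, read by MTT assay, with a stated time of 12 h; on this read-out lower numbers stand for stronger inhibition and higher numbers for weaker inhibition. Compound 1 `COc1ccc2c(=O)cc(/C=C/c3ccc(OC(F)(F)F)cc3)oc2c1` gives 9900 nM in this assay. Compound 2 `COc1cc(/C=C/c2cc(=O)c3c(OC)cc(OC)cc3o2)cc(OC)c1` gives 16700 nM in this assay. Compound 3 `COc1cc(OC)c2c(=O)cc(/C=C/c3ccc(Br)cc3)oc2c1` is recorded only as a limit of this assay, > 40000 nM, so no number is known for it. Among the three values shown, compound 3 is thus the one that rests on a limit rather than a measurement: the limit of > 40000 nM in this assay, at which 1 of the 3 values shown sits. Within the data shown here, none of the three differs from another in a single place, so no measured step of one change is available to guide expectations.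

Compound 4 `COc1cc(OC)c2c(=O)cc(/C=C/c3ccncc3)oc2c1` has not yet been tested. It differs from compound 3 in one place: pyridin-4-yl in place of 4-bromophenyl on a double-bonded chain carbon bound to a double-bonded chain carbon. Among the measured compounds shown here, with no measured step of this kind, the size and direction of the change can only be guessed, and the guess leans toward compound 4 remaining weak, since compound 3 itself gave only a limit. The expected step of an at least 1.3-fold lower number from compound 3 to compound 4 (0.12 log units; that floor lies within the scatter) is therefore modest and carries wide uncertainty. Compound 4 is expected to give about 30000 nM in this assay, within a range from 8000 nM to 100000 nM, and it may well again return only a limit.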

Compound 4, half-maximal inhibitory concentration: 18800 nM
For compound 4 the middle estimate is 1.6-fold (0.20 log units) above the measured one; low and high end bracket the measured number.
By their numbers in this assay, from the lowest: compounds 1, 2 and 4 (each within the scatter of the next). At a limit, above all of these: compound 3.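

In this assay, among these compounds, pyridin-4-yl in place of 4-bromophenyl on a double-bonded chain carbon bound to a double-bonded chain carbon gives the first step of one change, an at least 2.1-fold lower number from compound 3 to compound 4 (0.32 log units; beyond the scatter), which shows that the number responds to what is attached at this place on the chain. The entering ring brings 1 hydrogen-bond acceptor where the leaving ring has 0, and with this change compound 4 gives a true number of 18800 nM in this assay, while compound 3 remains a limit of > 40000 nM on the same read-out. Going by these compounds, the step can be stated only as a floor, and its full size stays unknown, because one of its two ends is a limit rather than a measurement: the limit of > 40000 nM in this assay, at which 1 of the 4 values shown sits.

This single pair cannot tell whether the change in the number goes with the loss of the bromine or with the entry of the ring nitrogen. An unsubstituted phenyl ring at this place would separate the two, and pyridin-3-yl would show whether the place of the ring nitrogen matters.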